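Anilide aryl swap on the oxadiazole amidoxime series

This account rests on a few compounds, and the source may have more. Where it says the series, first, only, none or still open, it means among the compounds named here.

Measured so far:
compound 1, `NS(=O)(=O)CC(=O)NCCSc1nonc1/C(=N/O)Nc1cccc(C(F)F)c1`, 1.5 h
compound 2, `NS(=O)(=O)CC(=O)NCCSc1nonc1/C(=N/O)Nc1ccc(F)c(C(F)F)c1`, 1.07 h

Both compounds share the same core and differ only in the aryl group on the amine nitrogen. In an ADME assay on microsomes from liver (Mus musculus) for metabolic stability (a lower number here means that the compound disappears faster, a higher number that the compound lasts longer), compound 1 gives 1.5 h and compound 2 gives 1.07 h. Within the data shown here, the single measured step, fluoro in place of hydrogen on an aromatic carbon, is a 1.4-fold lower number from compound 1 to compound 2 (0.15 log units; within the scatter), so the two compounds cannot be ordered against each other. Compound 2 holds the lower of the two numbers, but its nearest neighbour, compound 1, sits within the scatter of it.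

Compound 3, `NS(=O)(=O)CC(=O)NCCSc1nonc1/C(=N/O)Nc1cccc(Br)c1`, is not yet measured in this assay. Its change from compound 2 is 3-bromophenyl in place of 3-(difluoromethyl)-4-fluorophenyl on an amine nitrogen. Among the measured compounds shown here, no measured step touches the same kind of change: the one step known replaces hydrogen with fluoro and was within the scatter. The bromo-for-difluoromethyl-and-fluoro exchange is therefore uncharted here, and no direction can be drawn from the numbers shown. The expectation is that compound 3 gives a number close to compound 2, with the step of a 1.2-fold higher number from compound 2 to compound 3 (0.08 log units; within the scatter) expected to stay within the scatter. Compound 3 is estimated at 1.3 h, with a range from 0.6 h to 2.8 h.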

Compound 3, half-life: 0.918 h
Compound 3: the middle estimate sits 1.4-fold (0.15 log units) above what was measured; measured number inside the range.
By their numbers in this assay, from the lowest: compounds 3, 2 and 1 (each within the scatter of the next).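

In this assay, exchanging the whole aryl group on the amine nitrogen gives a 1.2-fold lower number from compound 2 to compound 3 (0.07 log units; within the scatter), and the narrower swap of bromo in place of difluoromethyl on an aromatic carbon gives a 1.6-fold lower number from compound 1 to compound 3 (0.21 log units; within the scatter). Both steps lie within the scatter, so this read-out does not separate 3-bromophenyl from 3-(difluoromethyl)-4-fluorophenyl or from the aryl group of compound 1, and the position has now been varied beyond a single hydrogen-to-fluoro change without a step that can be told from repeat noise. No line of supporting data bears on why these compounds sit so close together.

The three compounds shown all carry a halogen-containing phenyl on this nitrogen, so it remains open whether a phenyl bearing a carboxylic acid or a dimethylamino group, or a saturated ring such as cyclohexyl in place of the phenyl, would give a step beyond the scatter. The shared core and the sulfonamide-bearing side chain also stay constant throughout, which leaves open how much of the half-life in this assay depends on those parts rather than on the aryl group.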